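Notes on one series: from compound 2 to compound 4

A few compounds are considered here, and "the series" means these few. Any claim that something is new, unique, unknown or untested is made for them only; others in the source may bear on it.

Of the compounds shown here, three sharing one core have so far been measured in a functional assay on the whole organism for inhibition, with Rattus norvegicus as the target, read by paw edema, with a stated time of 30 min, at a dose of 20 mg/kg by the oral route; a lower number here means a weaker effect, a higher number a stronger effect of the compound at the dose given. Among the measured compounds shown here, compound 1 `COc1ccc(OCC2=NCCO2)cc1` gives 16.6%, and compound 3 `O=[N+]([O-])c1ccc(OCC2=NCCO2)cc1` gives 29.2%; the only single-point comparison among the measured compounds is a number 12.6 percentage points higher from compound 1 to compound 3 (beyond the scatter). Compound 2 `Brc1ccccc1OCC1=NCCO1` gives 20.1%, a number lying within the scatter of both compound 1 and compound 3, so no order among the three can be read from it.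

Compound 4 `Fc1ccccc1OCC1=NCCO1` differs from compound 2 in one place: fluoro in place of bromo on an aromatic carbon. For the measured compounds named here, no measured step exchanges one halogen for another. Going by the values given here, the single measured step, a number 12.6 percentage points higher from compound 1 to compound 3 (beyond the scatter), concerns a different kind of group at a different position and bears only loosely on this change. Among the compounds with values here, with no halogen-to-halogen precedent, the working expectation is no step beyond the scatter: the expected step of a number 0.1 percentage points lower from compound 2 to compound 4 (within the scatter) is set near zero, with a wide range reflecting the missing precedent. Compound 4 is therefore estimated at 20%, ranging from 8% to 32%.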

Compound 4, a percentage reported as inhibition, in the whole organism at one dose (the size of the read-out at that dose, not a potency): 20.6%
For compound 4 the middle estimate is 0.6 percentage points below the measured one, and the stated range covers the measured number.
By their numbers in this assay, from the lowest: compounds 1, 2, 4 and 3 (each within the scatter of the next, the first and the last beyond it).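

In this assay, among the compounds shown here, this first halogen exchange gives a number 0.5 percentage points higher from compound 2 to compound 4 (within the scatter), so fluoro in place of bromo, ortho to a group of 7 heavy atoms, produces no step that can be separated from the scatter at this single dose. For the compounds shown here, the only earlier single-place comparison, a number 12.6 percentage points higher from compound 1 to compound 3 (beyond the scatter), concerned methoxy and nitro at another position, whereas this pair gives the first direct reading of a change at this position. No measured information bears on why the read-out stays within the scatter here.

From the compounds shown here alone, whether an amine, a carboxylic acid or a longer chain at this position would give a step beyond the scatter remains open. Also open, going by these compounds, is whether fluoro and bromo would stay within the scatter of each other at the position carrying methoxy in compound 1.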